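A Succinimide Ring in Place of a Hydroxy Group

This account rests on a few compounds, and the source may have more. Where it says the series, first, only, none or still open, it means among the compounds named here.

Compound 1 `O=C1O[C@@H](CO)CN1c1ccc(-n2cc(-c3ccccn3)cn2)c(F)c1` carries a hydroxy group on a saturated chain carbon bound to a saturated ring carbon. In a physicochemical assay for lipophilicity, read by HPLC, measured as octanol-water partition (on this read-out lower numbers stand for lower lipophilicity and higher numbers for higher lipophilicity), compound 1 gives 1.67. For the measured compounds named here, only one other number is known: compound 2 `COC(=O)CC1CCN(C[C@H]2CN(c3ccc(-n4cc(-c5ccccn5)cn4)c(F)c3)C(=O)O2)CC1`, which in this assay gives 1.78, and the two compounds lie within the scatter of each other, so neither can be called more or less lipophilic than the other.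

Compound 3 `O=C1CCC(=O)N1C[C@H]1CN(c2ccc(-n3cc(-c4ccccn4)cn3)c(F)c2)C(=O)O1` has not yet been measured. It differs from compound 1 as follows: 2,5-dioxopyrrolidin-1-yl in place of hydroxy on a saturated chain carbon bound to a saturated ring carbon. Going by the values given here, the one measured step that bears on this change is a number 0.11 log units higher from compound 1 to compound 2 (within the scatter), which exchanged the same hydroxy group at the same place for a much larger 4-((methoxycarbonyl)methyl)piperidin-1-yl group and still moved the number only a little. On this basis, a small step, at most just beyond the scatter, is expected in this assay for compound 3 as well. The expected step of a number 0.23 log units higher from compound 1 to compound 3 (within the scatter) is therefore modest and upward. Compound 3 is estimated at 1.9, with a range from 1.5 to 2.4.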

Compound 3, partition coefficient: 1.58
Beside the measured number, compound 3's estimate is 0.32 log units above it; the range from low to high includes it.
By their numbers in this assay, from the lowest: compounds 3, 1 and 2 (each within the scatter of the next).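

Read in this assay, the exchange of hydroxy, which has 1 heavy atom and 1 hydrogen-bond donor, for 2,5-dioxopyrrolidin-1-yl, which has 7 heavy atoms, a five-membered non-aromatic ring and 0 hydrogen-bond donors, gives a number 0.09 log units lower from compound 1 to compound 3 (within the scatter). Exchanging 4-((methoxycarbonyl)methyl)piperidin-1-yl for 2,5-dioxopyrrolidin-1-yl at the same place gives a number 0.20 log units lower from compound 2 to compound 3 (within the scatter), so all three compounds now lie within the scatter of one another, and this place on a saturated chain carbon bound to a saturated ring carbon has taken two very different replacements for hydroxy without a step beyond the scatter. Nothing shown here accounts for how little these numbers differ.

The compounds shown leave open whether a carboxylic acid or a primary amine at this place would also stay within the scatter of compound 1. They also leave open whether a longer chain carrying the same 2,5-dioxopyrrolidin-1-yl group would stay within it.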